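This account rests on a few compounds, and the source may have more. Where it says the series, first, only, none or still open, it means among the compounds named here.

Of the compounds shown here, three of a shared core have been tested in an assay for inhibition of prostacyclin synthase (Homo sapiens), using microsomes; on this read-out higher numbers stand for weaker inhibition and lower numbers for stronger inhibition. Compound 1 `CSc1ccc(OC(C)(C)C2OCC(C/C=C\CCC(=O)O)C(c3cccnc3)O2)c([N+](=O)[O-])c1` carries a 4-methylthio-2-nitrophenoxy arm and gives 5000 nM in this assay. Compound 2 `Cc1ccc(C#N)c(OC(C)(C)C2OCC(C/C=C\CCC(=O)O)C(c3cccnc3)O2)c1` gives only a limit of the assay, > 100000 nM. Compound 3 `COc1ccc(OC(C)(C)C2OCC(C/C=C\CCC(=O)O)C(c3cccnc3)O2)cc1` likewise gives only a limit, > 100000 nM. The exchange of arms is costly: the change from compound 1 to compound 2 brings an at least 20-fold higher number from compound 1 to compound 2 (1.30 log units; beyond the scatter), and the change from compound 1 to compound 3 brings an at least 20-fold higher number from compound 1 to compound 3 (1.30 log units; beyond the scatter). Between compound 2 and compound 3 the step is a step that the two limits leave unreadable from compound 2 to compound 3, since both values rest on (the limit of > 100000 nM in this assay, at which 2 of the 3 values shown sit).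

Compound 3 therefore stands at the weak end of what this assay can report. Compound 4 `Cc1ccc(OC(C)(C)C2OCC(C/C=C\CCC(=O)O)C(c3cccnc3)O2)cc1` differs from it by methyl in place of methoxy on an aromatic carbon. For the measured compounds named here, no measured step covers exactly this swap, and the steps that reach compound 3 only show that compound 3 sits at a limit. The estimate for compound 4 therefore assumes a step of a number no higher from compound 3 to compound 4 (the limit leaves the size open), that is no change beyond the scatter. Compound 4 is expected to give about 100000 nM in this assay, within a range from 30000 nM to 300000 nM, most likely again as a limit.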

Compound 4, half-maximal inhibitory concentration: 25000 nM
Compound 4: middle estimate off by 4.0-fold (0.60 log units), on the high side, outside the stated range (below it).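

In this assay, for the compounds shown here, methyl in place of methoxy on an aromatic carbon para to a large group brings an at least 4.0-fold lower number from compound 3 to compound 4 (0.60 log units; beyond the scatter), so a change at this single position is enough to give a measured value where the earlier compounds offered only a limit, and the true size of the step stays open at that limit: the limit of > 100000 nM in this assay, at which 2 of the 4 values shown sit. The arm of compound 4 also separates from the nitrile-bearing arm, as 4-methylphenyl in place of 2-cyano-5-methylphenyl brings an at least 4.0-fold lower number from compound 2 to compound 4 (0.60 log units; beyond the scatter). The methyl arm still does not match the arm of compound 1, with a 5.0-fold higher number from compound 1 to compound 4 (0.70 log units; beyond the scatter), so the gap between that arm and the limit compounds is now partly filled by a much smaller group.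

The compounds shown leave open whether the step at this position follows from the methyl group itself or from the loss of methoxy, and how a chlorine atom, an ethyl group or a bare hydrogen on the same carbon would read. They also leave open how the difference from compound 1 divides between its nitro group and its methylthio group.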